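Changing the Aryl Group on a Shared Core

The source may hold more compounds than are shown below. What is called first, only, known or untested is meant among the compounds shown, and "the series" means these compounds.

In a functional assay on A549 cells (Homo sapiens) for antiproliferative activity, read by MTT assay, with a stated time of 48 h (on this read-out higher numbers stand for weaker inhibition and lower numbers for stronger inhibition), compound 1 (`COc1ccc(-c2cc3c(cn2)[nH]c(=O)n3-c2cc(OC)c(OC)c(OC)c2)cc1`) gives 1120 nM, and compound 2 (`COc1ccc(-c2cc3c(cn2)[nH]c(=O)n3-c2cc(OC)c(OC)c(OC)c2)cn1`) gives 1220 nM, so compound 2 stands level with compound 1 within the scatter. Compound 3 (`CCOc1ccc(-c2cc3c(cn2)[nH]c(=O)n3-c2cc(OC)c(OC)c(OC)c2)cc1F`) has not yet been measured. Its change from compound 2 is 4-ethoxy-3-fluorophenyl in place of 6-methoxypyridin-3-yl on an aromatic carbon, in words 4-ethoxy-3-fluorophenyl in place of 6-methoxypyridin-3-yl on an aromatic carbon. Among the compounds with values here, only one measured step bears on this: a 1.1-fold higher number from compound 1 to compound 2 (0.04 log units; within the scatter), the exchange of 4-methoxyphenyl for 6-methoxypyridin-3-yl, which stays within the scatter. Within the data shown here, no measured compound carries the ethoxy group or the fluorine, so that step is only a partial guide. In this assay, a small move to a lower number, not clearly beyond the scatter, is therefore expected: a 1.4-fold lower number from compound 2 to compound 3 (0.13 log units; within the scatter). The estimate for compound 3 is 900 nM, with an expected range of 300 nM to 2700 nM.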

Compound 3, half-maximal inhibitory concentration: 2540 nM
The estimate for compound 3 lay 2.8-fold (0.45 log units) below the measured number; the range from low to high includes it.
By their numbers in this assay, from the lowest: compounds 1 and 2 (each within the scatter of the next); then compound 3.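

In this assay this position, on an aromatic carbon next to the ring nitrogen, does respond to the aryl group: 4-ethoxy-3-fluorophenyl brings a 2.1-fold higher number from compound 2 to compound 3 (0.32 log units; beyond the scatter) and a 2.3-fold higher number from compound 1 to compound 3 (0.36 log units; beyond the scatter), both modest steps, while the earlier exchange of 4-methoxyphenyl for 6-methoxypyridin-3-yl stayed within the scatter. Compound 3 is therefore the weakest of the three here, and its change differs from compound 2 in the ring nitrogen, the ethoxy group and the fluorine all at once. Nothing available accounts for this loss.

No compound shown holds the ethoxy group without the fluorine, or the fluorine without the ethoxy group, so the share of each in the step stays open. Also open, from the compounds shown here alone, is how an amine or a longer alkoxy chain such as propoxy on this aryl ring would read in this assay.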